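This account rests on a few compounds, and the source may have more. Where it says the series, first, only, none or still open, it means among the compounds named here.

Working notes on the selenocyanate carbamate series.

Two compounds have numbers in a functional assay on HTB-54 cells (Homo sapiens) for cytotoxicity, read by MTT assay, with a stated time of 72 h; on this read-out lower numbers stand for stronger inhibition of growth and higher numbers for weaker inhibition of growth. Compound 1 `CCCOC(=O)Nc1ccc([Se]C#N)cc1` carries a propyl carbamate on the shared core; in this assay compound 1 gives 51900 nM. Compound 2 `N#C[Se]c1ccc(NC(=O)Oc2ccc(F)cc2)cc1` carries instead an aryl carbamate whose second ring bears a fluoro; in this assay compound 2 gives 48400 nM. Compound 2 thus holds the lower of the two numbers, but its gap to compound 1 lies within the scatter, so the two values cannot be separated and no order between them is claimed.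

Compound 3 `N#C[Se]c1ccc(NC(=O)Oc2ccccc2)cc1` is compound 2 without the fluoro: hydrogen in place of fluoro on an aromatic carbon. For the measured compounds named here, no measured pair makes this particular change, so there is no step to lean on. The swap of propyl for fluorophenyl between compound 1 and compound 2 moved the number very little, and the removal of a single fluorine is a smaller change than that, so nothing beyond the scatter is expected in either direction. Compound 3 is therefore estimated at 50000 nM in this assay, with a range from 20000 nM to 125000 nM. The step of a 1.0-fold higher number from compound 2 to compound 3 (0.01 log units; within the scatter) that this estimate implies is expected to stay within the scatter.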

Compound 3, concentration for total growth inhibition: 50200 nM
The estimate for compound 3 lay 1.0-fold (0.00 log units) below the measured number, within the range that was stated.
By their numbers in this assay, from the lowest: compounds 2, 3 and 1 (each within the scatter of the next).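

In this assay, hydrogen in place of fluoro on an aromatic carbon, para to a large group, gives a 1.0-fold higher number from compound 2 to compound 3 (0.02 log units; within the scatter), so the only pair shown for this change reveals no readable effect of the fluoro at this position. Phenyl in place of propyl gives a 1.0-fold lower number from compound 1 to compound 3 (0.01 log units; within the scatter), which means that the propyl carbamate and the unsubstituted phenyl carbamate cannot be told apart, and this single-place pair now supports what the comparison of compound 1 with compound 2, which differ in more than one place, could only suggest. Nothing in hand explains why these steps are so small.

The compounds shown leave open whether any group at this ring position, such as an amine or a carboxylic acid, would move the number beyond the scatter, since fluoro and hydrogen are the only two compared there. Going by these compounds, it also remains open whether a longer chain in place of propyl on the carbamate would separate from these three compounds, or whether a change to the selenocyanate itself, such as a thiocyanate, would do so.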